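A Methyl Added to the Phenoxy-Bearing Ring

A few compounds are considered here, and "the series" means these few. Any claim that something is new, unique, unknown or untested is made for them only; others in the source may bear on it.

Compound 2 `Cc1cc(CCC(=O)O)ccc1OCc1cccc(Oc2ccccc2)c1` gives 90% in a functional assay on cells for agonist activity at Free fatty acid receptor 1 (Homo sapiens), read by FLIPR and calcium flux; on this read-out lower numbers stand for smaller maximal responses and higher numbers for larger maximal responses. That places it second highest of the three measured numbers: compound 1 `Cc1cc(CCC(=O)O)ccc1OCc1cccc(Cl)c1` gives 60%, and compound 3 `Cc1ccc(OC(C)C)c(COc2ccc(CCC(=O)O)cc2C)c1` gives 154%. Compound 4 `Cc1cc(COc2ccc(CCC(=O)O)cc2C)cc(Oc2ccccc2)c1` differs from compound 2 by methyl in place of hydrogen on an aromatic carbon. Among the measured compounds shown here, the only measured single step, a number 30 percentage points higher from compound 1 to compound 2 (beyond the scatter), shows that a change on that same ring moved the maximal response beyond the scatter, although it exchanged chloro for phenoxy rather than adding a methyl. For the measured compounds named here, compound 3, which also carries a methyl and an alkoxy group, stands far above compound 2, but it differs in more than one place, so no single step is available. A modest rise is therefore expected, a number 10 percentage points higher from compound 2 to compound 4 (within the scatter). Compound 4 is estimated at 100%, within a range from 75% to 130%.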

Compound 4, largest response reached (reported as percent of maximum), in percent of the reference or control that the assay uses: 85%
The estimate for compound 4 lay 15 percentage points above the measured number, within the range that was stated.
By their numbers in this assay, from the lowest: compound 1; then compounds 4 and 2 (each within the scatter of the next); then compound 3.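

In this assay, the methyl on this aromatic carbon, meta to a phenoxy group, gives a number 5 percentage points lower from compound 2 to compound 4 (within the scatter) and so leaves the maximal response indistinguishable from that of the parent. Unlike the earlier exchange of chloro for phenoxy, this change on the same ring produces no readable shift. Nothing available explains this result.

From the compounds shown here alone, it remains open whether a methoxy group, an amine or a longer chain on this carbon would alter the maximal response. Going by these compounds, it is also open whether the methyl would behave alike with chloro in place of phenoxy.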